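This account rests on a few compounds, and the source may have more. Where it says the series, first, only, none or still open, it means among the compounds named here.

Compound 1 `ClCc1ccccc1Cn1cnc2c(Cl)nc(Cl)nc21`: 1380 nM
Compound 2 `ClCc1ccccc1Cn1cnc2c(Cl)ncnc21`: 1950 nM
Compound 3 `ClCc1cccc(Cn2cnc3c(Cl)ncnc32)c1`: 1660 nM

In a functional assay on M14 cells (Homo sapiens) for cytotoxicity, read by sulforhodamine B assay, with a stated time of 48 h (on this read-out lower numbers stand for stronger inhibition of growth and higher numbers for weaker inhibition of growth), compound 1 gives 1380 nM, compound 2 gives 1950 nM and compound 3 gives 1660 nM. Compound 1 differs from compound 2 by chloro in place of hydrogen on an aromatic carbon, and that change produced a 1.4-fold lower number from compound 2 to compound 1 (0.15 log units; within the scatter). The difference between the cores of compound 2 and compound 3 is not broken down here. Compound 4 `ClCc1cccc(Cn2cnc3c(Cl)nc(Cl)nc32)c1` has not yet been measured in this assay; it differs from compound 3 by chloro in place of hydrogen on an aromatic carbon, the same change as from compound 2 to compound 1. Because the earlier change gave a 1.4-fold lower number from compound 2 to compound 1 (0.15 log units; within the scatter), a step of similar size is expected here, a 1.3-fold lower number from compound 3 to compound 4 (0.12 log units; within the scatter). Compound 4 is therefore estimated at 1250 nM, with a likely range from 700 nM to 2300 nM.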

Compound 4, concentration for 50% growth inhibition: 1770 nM
Compound 4: middle estimate off by 1.4-fold (0.15 log units), on the low side, and the stated range covers the measured number.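

In this assay, putting chloro in place of hydrogen on the core of compound 3 gave a 1.1-fold higher number from compound 3 to compound 4 (0.03 log units; within the scatter). Set beside the earlier case, the two steps cannot be told apart: the same change on two cores in this assay, a 1.4-fold lower number (0.15 log units; within the scatter) from compound 2 to compound 1 and a 1.1-fold higher number (0.03 log units; within the scatter) from compound 3 to compound 4, 1.5-fold (0.18 log units) apart, within the scatter of two such steps

This shows that the change behaves alike on these two cores, in that neither step leaves the scatter, but it does not show a real effect of the chloro that carries from one core to the other, and two cores are too few to speak for the series.

The compounds shown leave open what an amine or a methoxy group would do on the aromatic carbon between two ring nitrogen atoms. They also leave open whether any such group would give a step beyond the scatter on either core.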